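Dimethylamino in Place of Nitro: Cytotoxicity Outlook

A few compounds are considered here, and "the series" means these few. Any claim that something is new, unique, unknown or untested is made for them only; others in the source may bear on it.

A set of ureas built on a shared core was examined in an ADME assay on HEK293 cells (Homo sapiens) for cytotoxicity, with a stated time of 72 h; on this read-out higher numbers stand for an effect only at larger amounts of compound and lower numbers for an effect already at smaller amounts. Compound 1, `Cc1cc(NC(=O)Nc2cccc([N+](=O)[O-])c2)c2ccccc2n1`, stands at a limit of this assay: compound 1 gives > 25000 nM, which is a limit of the measurement and not a number. Compound 2, `Cc1cc(NC(=O)Nc2ccc3[nH]cnc3c2)c2ccccc2n1`, likewise reaches only a limit, > 25000 nM. Compound 3, `Cc1cc(NC(=O)Nc2cc(F)cc(F)c2)c2ccccc2n1`, also gives only a limit, > 25000 nM. All three values therefore rest at the same point, as summarised by the limit of > 25000 nM in this assay, at which 3 of the 3 values shown sit, and no step between measured compounds can be drawn; the three values show only that none of these compounds produces a measurable effect within the range tested.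

Compound 4, `Cc1cc(NC(=O)Nc2cccc(N(C)C)c2)c2ccccc2n1`, has not yet been measured. It differs from compound 1 by dimethylamino in place of nitro on an aromatic carbon. Because every measured value sits at the limit (the limit of > 25000 nM in this assay, at which 3 of the 3 values shown sit), the expected step that the limit leaves unreadable from compound 1 to compound 4 is essentially none, with no movement beyond the scatter anticipated in either direction. Compound 4 is therefore expected to give about 30000 nM in this assay, within a range from 15000 nM to 100000 nM, and most likely to be reported once more as a limit rather than a number.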

Compound 4, half-maximal effective concentration: > 25000 nM
Compound 4 gave a limit, no number; the forecaster's own chance of this, stated with the estimate: 85%; the middle value lies beyond the limit too.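

Compound 4, like compound 1, rests at a limit in this assay, so no step between compound 1 and compound 4 can be read: the limit of > 25000 nM in this assay, at which 4 of the 4 values shown sit.

The compounds shown leave open where any of them would produce a measurable effect in this assay, and so whether dimethylamino in place of nitro changes the read-out at all.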